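Hydroxyphenyl in place of fluorophenyl on the amide carbonyl

The source may hold more compounds than are shown below. What is called first, only, known or untested is meant among the compounds shown, and "the series" means these compounds.

Of the compounds shown here, three sharing one core have been tested in an ADME assay on J774 cells (Mus musculus, strain BALB/c) for cytotoxicity, read by resazurin assay, with a stated time of 72 h; on this read-out higher numbers stand for lower toxicity in this test and lower numbers for higher toxicity in this test. Compound 1 `CC(/C=N/Nc1ccc([N+](=O)[O-])cc1)=N\NC(=O)c1ccc(C(F)(F)F)cc1` gives 78700 nM in this assay. Compound 2 `CC(/C=N/Nc1ccc([N+](=O)[O-])cc1)=N\NC(=O)c1ccccc1I` gives 40000 nM. Compound 3 `CC(/C=N/Nc1ccc([N+](=O)[O-])cc1)=N\NC(=O)c1ccccc1F` returns only a limit of the assay, > 100000 nM, and so stands at the limit of > 100000 nM in this assay, at which 1 of the 3 values shown sits, rather than at a number. Within the data shown here, the one measured step that reaches compound 3 is an at least 2.5-fold higher number from compound 2 to compound 3 (0.39 log units; beyond the scatter), which moves toward lower toxicity and ends at the limit.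

Compound 4 `CC(/C=N/Nc1ccc([N+](=O)[O-])cc1)=N\NC(=O)c1ccc(O)cc1` is not yet measured in this assay. It differs from compound 3 thus: 4-hydroxyphenyl in place of 2-fluorophenyl on a carbonyl carbon. Among the measured compounds shown here, no measured step exchanges a halogen on that ring for a hydroxyl, so none bears directly on this change; the step from compound 2 to compound 3 only shows that the fluorophenyl compound sits at or past the limit. With all three measured compounds lying in one region of this assay, compound 4 is expected to sit in that same region, and the step of a number no higher from compound 3 to compound 4 (the limit leaves the size open) is expected to stay within the scatter. The estimate for compound 4 in this assay is therefore 100000 nM, with a range from 40000 nM to 300000 nM, and a fair chance that only a limit is reported again.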

Compound 4, half-maximal cytotoxic concentration: 51000 nM
Estimate against measurement, compound 4: 2.0-fold (0.29 log units) above; the range from low to high includes it.
By their numbers in this assay, from the lowest: compounds 2, 4 and 1 (each within the scatter of the next). At a limit, above all of these: compound 3.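

In this assay, on these data alone, the exchange of 2-fluorophenyl for 4-hydroxyphenyl on a carbonyl carbon reads as an at least 1.9-fold lower number from compound 3 to compound 4 (0.29 log units; that floor lies within the scatter), so this change gives a measured number at this position, while the true size of the step remains unknown. Measured against the other two compounds, the hydroxylated ring cannot be separated from them, with a 1.3-fold higher number from compound 2 to compound 4 (0.11 log units; within the scatter) and a 1.5-fold lower number from compound 1 to compound 4 (0.19 log units; within the scatter), so 4-hydroxyphenyl, 2-iodophenyl and the trifluoromethyl-bearing phenyl ring all fall in one region of this read-out. The step from the fluorinated compound alone stays unsized, as compound 3 carries a limit and not a number: the limit of > 100000 nM in this assay, at which 1 of the 4 values shown sits.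

The groups 4-hydroxyphenyl and 2-fluorophenyl differ both in the substituent and in its place on the ring, and the compounds shown do not separate these two differences. As far as these compounds go, how an amine or a carboxylic acid on that ring would read in this assay also stays open.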